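Hydrazone series on a shared benzothiazolyl-benzoyl core

A few compounds are considered here, and "the series" means these few. Any claim that something is new, unique, unknown or untested is made for them only; others in the source may bear on it.

Measured compounds:
compound 1, `COc1ccc(O)c(/C=N/NC(=O)c2ccc(-c3nc4ccccc4s3)cc2)c1`, 6500 nM
compound 2, `O=C(N/N=C/c1ccccc1O)c1ccc(-c2nc3ccccc3s2)cc1`, 5550 nM

Within the data shown here, in an assay on isolated protein for inhibition of Maltase-glucoamylase (Homo sapiens), with a stated time of 15 min (on this read-out lower numbers stand for stronger inhibition and higher numbers for weaker inhibition), compound 2 gives 5550 nM, the lower of the two numbers so far, but its only neighbour, compound 1, sits within the scatter of it; no order between the two can be read. Among the measured compounds shown here, the one measured step, a 1.2-fold lower number from compound 1 to compound 2 (0.07 log units; within the scatter), shows that taking a methoxy off the aryl ring of the hydrazone leaves this assay unchanged.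

Compound 3, `O=C(N/N=C/c1ccc(O)c(O)c1)c1ccc(-c2nc3ccccc3s2)cc1`, is not yet measured. It differs from compound 2 by 3,4-dihydroxyphenyl in place of 2-hydroxyphenyl on a carbon with a double bond to nitrogen. For the measured compounds named here, the step from compound 1 to compound 2 touches the same ring and is the only measured change that bears on it; it was within the scatter. Going by the values given here, the present change is larger in kind, since it moves a hydroxy and adds a second one, but no measured step reports what that does here. The expectation is therefore a step in this assay of no size beyond the scatter, with a slight lean to a lower number, a 1.2-fold lower number from compound 2 to compound 3 (0.09 log units; within the scatter). Compound 3 is estimated at 4500 nM, with a range from 1500 nM to 14000 nM.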

Compound 3, half-maximal inhibitory concentration: 15100 nM
Compound 3: middle estimate off by 3.4-fold (0.53 log units), on the low side, outside the stated range (above it).
By their numbers in this assay, from the lowest: compounds 2 and 1 (each within the scatter of the next); then compound 3.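

The aryl group on the carbon with a double bond to nitrogen can move the number in this assay: 3,4-dihydroxyphenyl in place of 2-hydroxyphenyl gives a 2.7-fold higher number from compound 2 to compound 3 (0.43 log units; beyond the scatter), whereas removing the methoxy earlier gave only a 1.2-fold lower number from compound 1 to compound 2 (0.07 log units; within the scatter). The exchange for 2-hydroxy-5-methoxyphenyl points the same way, with a 2.3-fold higher number from compound 1 to compound 3 (0.37 log units; beyond the scatter), so 3,4-dihydroxyphenyl stands apart from the two aryl groups of compound 1 and compound 2, which remain within the scatter of each other. No measurement on hand gives a reason for this shift.

Compound 3 alters both the placing and the number of the hydroxy groups in a single change, and the compounds shown do not separate these two contributions. Also open, on these data alone, is whether an unsubstituted phenyl, or an amine or a carboxylic acid on this aryl ring, would give a number lower than those of compound 1 and compound 2, or whether any group here can improve on them at all.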